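Hexyl on the sulfonamide nitrogen: from urea to carbamate core

A few compounds are considered here, and "the series" means these few. Any claim that something is new, unique, unknown or untested is made for them only; others in the source may bear on it.

Measured compounds:
compound 1 `CCCCCCNS(=O)(=O)NC(=O)Nc1c(C(C)C)cccc1C(C)C` — 8100 nM
compound 2 `CCCCCCN(CCCCCC)S(=O)(=O)NC(=O)Nc1c(C(C)C)cccc1C(C)C` — 510 nM
compound 3 `CCCCCCNS(=O)(=O)NC(=O)Oc1c(C(C)(C)C)cc(C)cc1C(C)(C)C` — 19400 nM

The three compounds were tested in an assay on liver for inhibition of sterol O-acyltransferase 1 (Rattus norvegicus), using microsomes; on this read-out higher numbers stand for weaker inhibition and lower numbers for stronger inhibition. Compound 1 gives 8100 nM, and compound 2, which carries the change (hexyl in place of hydrogen on a sulfonamide nitrogen), gives 510 nM; the step is a 16-fold lower number from compound 1 to compound 2 (1.20 log units; beyond the scatter). Compound 3, built on a different core, gives 19400 nM, the highest number of the three. The difference between the two cores is not broken down here.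

Compound 4 `CCCCCCN(CCCCCC)S(=O)(=O)NC(=O)Oc1c(C(C)(C)C)cc(C)cc1C(C)(C)C` is not yet measured. It differs from compound 3 by hexyl in place of hydrogen on a sulfonamide nitrogen, the same change as that from compound 1 to compound 2, made on the same kind of place in both pairs. If the step carries over to the core of compound 3, a similar drop in the number is expected. Because the step from compound 1 to compound 2 was a 16-fold lower number from compound 1 to compound 2 (1.20 log units; beyond the scatter), compound 4 is expected to show a 13-fold lower number from compound 3 to compound 4 (1.11 log units; beyond the scatter) in this assay, though transfer between cores is uncertain. Compound 4 is therefore estimated at 1500 nM, with a range from 400 nM to 6000 nM.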

Compound 4, half-maximal inhibitory concentration: 4300 nM
Compound 4: the middle estimate sits 2.9-fold (0.46 log units) below what was measured; measured number inside the range.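

In this assay, hexyl in place of hydrogen on a sulfonamide nitrogen lowers the number on the second core as well, with a 4.5-fold lower number from compound 3 to compound 4 (0.65 log units; beyond the scatter), so the direction of the step carries over between the two cores shown. The size of the step does not carry over: the same change on two cores in this assay, a 16-fold lower number (1.20 log units; beyond the scatter) from compound 1 to compound 2 and a 4.5-fold lower number (0.65 log units; beyond the scatter) from compound 3 to compound 4, 3.5-fold (0.55 log units) apart, beyond the scatter of two such steps

These two pairs therefore show that, in this series, a step measured on one core gives the direction on the other but cannot be relied on for its size, and they do not show which of the several differences between the cores accounts for the gap.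

The compounds shown leave open whether a longer chain, a shorter chain or a chain ending in a carboxylic acid, in place of hexyl on the sulfonamide nitrogen, would give steps that agree more closely across the two cores. They also leave open whether the direction of the step would hold on a third core.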